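Phenyl in Place of Cyclopropyl and Microsomal Stability

A few compounds are considered here, and "the series" means these few. Any claim that something is new, unique, unknown or untested is made for them only; others in the source may bear on it.

Three compounds share one core. Compound 1 `C[C@H](Nc1nc(N)nc(N)c1C#N)c1cc(=O)n2cc(F)ccc2c1-c1ccccc1` was submitted to an ADME assay on microsomes from liver (Homo sapiens), read by LC-MS, using NADPH, with a stated time of 30 min, tested at 1 uM (on this read-out lower numbers stand for a less stable compound and higher numbers for a more stable compound), but for compound 1 the result stands as "not determined" (no result reported). For the measured compounds named here, compound 2 `C[C@H](Nc1nc(N)nc(N)c1C#N)c1c(-c2ccccc2)c(=O)n2cc(F)ccc2c1C1CC1` is the only compound with a number: in this assay compound 2 gives 91%, which places it near the top of the read-out, where little of the compound has been lost over the incubation. Compound 3 `C[C@H](Nc1nc(N)nc(N)c1C#N)c1c(-c2ccccc2)c(=O)n2cc(F)ccc2c1-c1ccccc1` has not yet been measured; it differs from compound 2 in one place, (phenyl in place of cyclopropyl on an aromatic carbon). Going by the values given here, no measured step connects two compounds in this set, so nothing here tells how large an effect such a change has. Since compound 2 already stands high, there is little room above it, and the expectation is therefore a step of modest size, downward or none beyond the scatter, a number 11 percentage points lower from compound 2 to compound 3 (beyond the scatter). Compound 3 is accordingly estimated at 80%, with a range from 55% to 97%. The range is wide because compound 2 gives 91% as the only anchor available.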

Compound 3, percent of the compound remaining: 98%
The estimate for compound 3 lay 18 percentage points below the measured number; the measured number lies above the stated range.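

In this assay, for the compounds shown here, phenyl in place of cyclopropyl on this aromatic carbon gives a number 7 percentage points higher from compound 2 to compound 3 (within the scatter), the first measured step at this position. Within this one pair, the position therefore carries either group, cyclopropyl with 3 heavy atoms or phenyl with 6, with no difference that the read-out can separate from the usual scatter. Nothing among the data shown speaks to what lies behind this result.

Going by these compounds, the pair says nothing about a group of another kind on this aromatic carbon, such as an amine or a carboxylic acid, and it remains open whether either would stay at the high end of the read-out, as cyclopropyl and phenyl do. Any step involving compound 1, which stands at "not determined" (no result reported), cannot be read, so the shared core is not compared here with and without a further group, and what the substituents on that core contribute in this assay also remains open.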